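Benzylamine variation on the bis(trifluoromethyl)sulfonamide series

The compounds below may be only part of what the source reports. "The series", "measured", "known", "first", "only" and "open" are said of these compounds alone.

Compound 3 `O=S(=O)(NCCCNCC1COc2ccccc2O1)c1cc(C(F)(F)F)cc(C(F)(F)F)c1` gives 2500 nM in a functional assay on MCF7 cells (Homo sapiens) for inhibition, read by MTT assay, with a stated time of 72 h; a lower number here means a stronger inhibitor of growth, a higher number a weaker inhibitor of growth; it stands second highest of the three numbers, nearest compound 2 `O=S(=O)(NCCCNCc1ccc(Cl)c(Cl)c1)c1cc(C(F)(F)F)cc(C(F)(F)F)c1` with 2400 nM and furthest from compound 1 `O=S(=O)(NCCCNCc1ccccc1Cl)c1cc(C(F)(F)F)cc(C(F)(F)F)c1` with 8800 nM. The steps bearing on it were a 3.5-fold lower number from compound 1 to compound 3 (0.55 log units; beyond the scatter) and a 1.0-fold higher number from compound 2 to compound 3 (0.02 log units; within the scatter), with a 3.7-fold lower number from compound 1 to compound 2 (0.56 log units; beyond the scatter) for comparison. Compound 4 `O=S(=O)(NCCCNCc1ccc(C(F)(F)F)cc1)c1cc(C(F)(F)F)cc(C(F)(F)F)c1` carries 4-(trifluoromethyl)phenyl in place of 2,3-dihydro-1,4-benzodioxin-2-yl on a saturated chain carbon bound to an amine nitrogen. Exchange between two aryl groups on this carbon gave no step beyond the scatter from compound 2 to compound 3, so in this assay the step from compound 3 to compound 4 is expected to be no change at the digits printed from compound 3 to compound 4 (within the scatter), none beyond the scatter. Compound 4 is therefore estimated at 2500 nM, within 1000 nM to 7000 nM.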

Compound 4, concentration for 50% growth inhibition: 1400 nM
The estimate for compound 4 lay 1.8-fold (0.25 log units) above the measured number; the range from low to high includes it.
By their numbers in this assay, from the lowest: compounds 4, 2 and 3 (each within the scatter of the next); then compound 1.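

In this assay, the steps of a 1.8-fold lower number from compound 3 to compound 4 (0.25 log units; within the scatter) and a 1.7-fold lower number from compound 2 to compound 4 (0.23 log units; within the scatter) show that 4-(trifluoromethyl)phenyl on this saturated chain carbon stays level with the two earlier groups, even though it has no hydrogen-bond acceptors and 2,3-dihydro-1,4-benzodioxin-2-yl does. Only 2-chlorophenyl stands apart, and a 6.3-fold lower number from compound 1 to compound 4 (0.80 log units; beyond the scatter) is the largest step seen at this position. No evidence on the reason for these steps is available. Still open, as far as these compounds go, is whether 4-chlorophenyl or a pyridinyl group on this carbon would stay with compound 2, compound 3 and compound 4 or fall with compound 1.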